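A few compounds are considered here, and "the series" means these few. Any claim that something is new, unique, unknown or untested is made for them only; others in the source may bear on it.

Compound 1 `O=C1/C(=C/c2ccncc2)CN(S(=O)(=O)c2ccc(C(F)(F)F)cc2)C/C1=C\c1ccccc1F`: 11100 nM
Compound 2 `Cc1ccc(S(=O)(=O)N2C/C(=C\c3ccncc3)C(=O)/C(=C/c3ccccc3C(F)(F)F)C2)cc1`: 5590 nM

Both values come from a functional assay on SMMC-7721 cells (Homo sapiens) for cytotoxicity, read by MTT assay, with a stated time of 24 h; on this read-out higher numbers stand for weaker inhibition and lower numbers for stronger inhibition. Compound 2 stands within the usual scatter of compound 1, so these two numbers cannot be ranked. Compound 3 `O=C1/C(=C/c2ccncc2)CN(S(=O)(=O)c2ccc(C(F)(F)F)cc2)C/C1=C\c1ccccc1C(F)(F)F` is compound 2 with a single change: trifluoromethyl in place of methyl on an aromatic carbon. Trifluoromethyl takes the place of methyl on an aromatic carbon, para to a large group, which turns 4-methylphenyl into 4-(trifluoromethyl)phenyl. Among the measured compounds shown here, no measured pair shows this change alone. The nearest guide is compound 1, which also carries 4-(trifluoromethyl)phenyl and gives 11100 nM, a value within the scatter of compound 2 at 5590 nM. No step beyond the scatter is therefore expected in this assay. The estimated change a 1.1-fold higher number from compound 2 to compound 3 (0.03 log units; within the scatter) is small, with no firm direction. The expected value for compound 3 is 6000 nM, with an estimated range of 2500 nM to 14000 nM.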

Compound 3, half-maximal inhibitory concentration: 3840 nM
Compound 3: the middle estimate sits 1.6-fold (0.19 log units) above what was measured, within the range that was stated.
By their numbers in this assay, from the lowest: compounds 3, 2 and 1 (each within the scatter of the next, the first and the last beyond it).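

In this assay, the exchange of 4-methylphenyl for 4-(trifluoromethyl)phenyl gives a 1.5-fold lower number from compound 2 to compound 3 (0.16 log units; within the scatter) and so cannot be ranked, which means that either group can sit at this position, para to a large group, without a readable change in this assay. Among the compounds shown here, the other aromatic ring gives the first step beyond the scatter: going from fluoro to trifluoromethyl on that ring gives a 2.9-fold lower number from compound 1 to compound 3 (0.46 log units; beyond the scatter), a modest gain in inhibition. No measurement here explains either result.

As far as these compounds go, it remains open whether the gain from fluoro to trifluoromethyl would also appear with 4-methylphenyl in place of 4-(trifluoromethyl)phenyl. The compounds shown also leave open how a methoxy group, an amine or a carboxylic acid would behave at either position.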